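Swapping a Sulfur Group for Carboxy in a Cell Toxicity Test

The source may hold more compounds than are shown below. What is called first, only, known or untested is meant among the compounds shown, and "the series" means these compounds.

Measured so far in an ADME assay on HEK293 cells (Homo sapiens) for cytotoxicity, with a stated time of 72 h; on this read-out higher numbers stand for an effect only at larger amounts of compound and lower numbers for an effect already at smaller amounts:
- compound 1 `Cc1cc(NC(=O)Nc2ccc(C(N)=O)cc2)c2ccccc2n1`: > 25000 nM (a limit of the assay, not a number)
- compound 2 `Cc1cc(NC(=O)Nc2ccc(SC(F)(F)F)cc2)c2ccccc2n1`: 13000 nM

For the measured compounds named here, compound 2 gives the only actual number so far, 13000 nM. The next molecule, compound 3 `Cc1cc(NC(=O)Nc2ccc(C(=O)O)cc2)c2ccccc2n1`, carries carboxy in place of (trifluoromethyl)sulfanyl on an aromatic carbon. Going by the values given here, one measured step bears on this change: an at least 1.9-fold lower number from compound 1 to compound 2 (0.28 log units; that floor lies within the scatter). Compound 1 carries carbamoyl, which, like carboxy, contains a carbonyl, so that step, read backwards, is the nearest guide. A change of similar size toward a higher number is therefore expected, and it may not clear the usual scatter. The expected change is a 1.9-fold higher number from compound 2 to compound 3 (0.28 log units; within the scatter). For compound 3 the estimated value is 25000 nM, with an expected range from 12000 nM to 50000 nM.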

Compound 3, half-maximal effective concentration: > 25000 nM
Compound 3 was reported as a limit (the forecaster's own chance of this, stated with the estimate: 65%); the middle value lies on the limit itself.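

Compound 3 gives > 25000 nM in this assay, which is a limit of the assay and not a number. Carboxy is a second group with a carbonyl at this place on the aromatic ring, and replacing (trifluoromethyl)sulfanyl with it gives an at least 1.9-fold higher number from compound 2 to compound 3 (0.28 log units; that floor lies within the scatter), so the change points the same way as the earlier step read backwards, though only as a floor. The step between the two compounds carrying carbonyl groups cannot be read, so carboxy and carbamoyl cannot be ranked here, and the comparison is capped: the limit of > 25000 nM in this assay, at which 2 of the 3 values shown sit.

As far as these compounds go, it remains open whether a group such as an amine, a methyl ester or a chlorine atom in this place would give a number under that limit. From the compounds shown here alone, how far compound 3 truly lies from compound 2 also stays unknown.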